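Ethyl on an aromatic nitrogen of compound 3

The source may hold more compounds than are shown below. What is called first, only, known or untested is meant among the compounds shown, and "the series" means these compounds.

In an in vivo ADME assay on the whole organism (strain Sprague-Dawley) for pharmacokinetics, with Rattus norvegicus as the target, at a dose of 5 mg/kg by the oral route (a higher number here means that a larger share of the oral dose reaches the circulation, a lower number that a smaller share of the oral dose reaches the circulation), compound 1 `Nc1ccccc1NC(=O)c1ccc(CN2Cc3ccccc3C2=O)cc1` gives 34% and compound 2 `Nc1ccccc1NC(=O)c1ccc(Cn2cnc3ccsc3c2=O)cc1` gives 47% while compound 3 `Nc1ccccc1NC(=O)c1ccc(Cn2c(=O)[nH]c3ccsc3c2=O)cc1` gives 47% in the same test. Compound 3 thus stands level with compound 2, the two together holding the highest of the three numbers, and its gap to compound 1 lies beyond the scatter.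

The change leading to compound 4 `CCn1c(=O)n(Cc2ccc(C(=O)Nc3ccccc3N)cc2)c(=O)c2sccc21` is ethyl in place of hydrogen on an aromatic nitrogen with the rest of the structure kept. Going by the values given here, no two measured compounds differ in one place only, so the series offers no direct measure of this change. Starting from compound 3 at 47% only a small fall is expected, and none beyond the scatter. The estimated step of a number 5 percentage points lower from compound 3 to compound 4 (within the scatter) is therefore a tentative one. For compound 4 the expected value is 42% with an estimated range from 25% to 60% as the measurement is awaited.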

Compound 4, oral bioavailability: 64%
Compound 4: the middle estimate sits 22 percentage points below what was measured, and the stated range ends below it.
By their numbers in this assay, from the lowest: compound 1; then compounds 2 and 3 (each within the scatter of the next); then compound 4.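

In this assay, going by these compounds alone, ethyl in place of hydrogen on an aromatic nitrogen gives a number 17 percentage points higher from compound 3 to compound 4 (beyond the scatter), the first comparison between compounds that differ in one place. This position therefore has a measurable bearing on the oral read-out, and the hydrogen on this nitrogen is not required for oral exposure in this test. No measurement at hand bears on the reason for the step.

As far as these compounds go, this single pair does not show whether the step depends on the size of the group or on its nature, so methyl, a longer chain such as propyl and a chain ending in an amine or a carboxylic acid remain open at this nitrogen. From the compounds shown here alone, whether ethyl would give a similar step on another core also remains open.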